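The source may hold more compounds than are shown below. What is called first, only, known or untested is meant among the compounds shown, and "the series" means these compounds.

Three compounds share one core and differ only in the aryl group on the sulfonamide nitrogen: compound 1 `Cc1noc(NS(=O)(=O)c2ccc(N/C=C\C(=O)c3cc4ccccc4oc3=O)cc2)c1C`, compound 2 `Cc1cc(C)nc(NS(=O)(=O)c2ccc(N/C=C\C(=O)c3cc4ccccc4oc3=O)cc2)n1` and compound 3 `Cc1cc(NS(=O)(=O)c2ccc(N/C=C\C(=O)c3cc4ccccc4oc3=O)cc2)nc(C)n1`. In a functional assay on T47D cells (Homo sapiens) for cytotoxicity, read by sulforhodamine B assay, with a stated time of 48 h (a higher number here means a weaker inhibitor, a lower number a stronger inhibitor), compound 1 gives 68400 nM, compound 2 gives 62200 nM and compound 3 gives 100000 nM. Compound 3 thus carries the largest of the three numbers, yet a 1.5-fold higher number from compound 1 to compound 3 (0.16 log units; within the scatter) and a 1.6-fold higher number from compound 2 to compound 3 (0.21 log units; within the scatter), like a 1.1-fold lower number from compound 1 to compound 2 (0.04 log units; within the scatter), all lie within the scatter. Compound 4 `O=C(/C=C\Nc1ccc(S(=O)(=O)Nc2ccc3cn[nH]c3c2)cc1)c1cc2ccccc2oc1=O` continues this series with 1H-indazol-6-yl in place of 2,6-dimethylpyrimidin-4-yl on a sulfonamide nitrogen. Since every earlier swap at this position left the number within the scatter, the step of a 1.3-fold lower number from compound 3 to compound 4 (0.10 log units; within the scatter) is expected to be small. Compound 4 is therefore estimated at 80000 nM, in a range from 30000 nM to 200000 nM.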

Compound 4, half-maximal inhibitory concentration: 96500 nM
Compound 4: the middle estimate sits 1.2-fold (0.08 log units) below what was measured; the range from low to high includes it.
By their numbers in this assay, from the lowest: compounds 2, 1, 4 and 3 (each within the scatter of the next).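

Putting the two-ring 1H-indazol-6-yl group, with its hydrogen-bond donor, on the sulfonamide nitrogen gives a 1.0-fold lower number from compound 3 to compound 4 (0.02 log units; within the scatter), while the comparisons with the other two compounds give a 1.6-fold higher number from compound 2 to compound 4 (0.19 log units; within the scatter) and a 1.4-fold higher number from compound 1 to compound 4 (0.15 log units; within the scatter). In this assay, even this larger change of ring type therefore leaves all four compounds indistinguishable. Nothing available explains this flat result. Still open, going by these compounds, is whether a carboxylic acid or an amine on this aryl group, or a plain alkyl chain in its place, would shift the number beyond the scatter.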